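Replacing the Hydroxycyclohexylamino Arm with a Methyl Amide

A few compounds are considered here, and "the series" means these few. Any claim that something is new, unique, unknown or untested is made for them only; others in the source may bear on it.

Compound 1 `O=C(O)c1cccc(CNc2cc(C(F)(F)F)cc3[nH]ncc23)c1` and compound 2 `OC1CCCC(Nc2cccc(CNc3cc(C(F)(F)F)cc4[nH]ncc34)c2)C1` share one core and differ at a single group on the aromatic ring. In an assay for inhibition of Tryptophan 2,3-dioxygenase (Homo sapiens), with stated times of 10 min and 60 min (a lower number here means a stronger inhibitor, a higher number a weaker inhibitor), compound 1 gives 1690 nM. For compound 2 this assay reports only a limit, > 100000 nM. Compound 2 therefore stands at the weak end of the two measured values (the limit of > 100000 nM in this assay, at which 1 of the 2 values shown sits). The step of an at least 59-fold higher number from compound 1 to compound 2 (1.77 log units; beyond the scatter) shows that putting (3-hydroxycyclohexyl)amino in place of carboxy carried a large loss. Compound 3 `CNC(=O)c1cccc(CNc2cc(C(F)(F)F)cc3[nH]ncc23)c1` differs from compound 2 by methylcarbamoyl in place of (3-hydroxycyclohexyl)amino on an aromatic carbon, which removes the group that accompanied that loss and installs a smaller substituent of the same kind as the carboxy of compound 1. Within the data shown here, the only measured step bearing on this change is the one above, and it was large; a large move in the opposite direction, toward a lower number, is expected. Compound 3 is estimated to give 3000 nM in this assay, between 800 nM and 15000 nM, an expected step of an at least 33-fold lower number from compound 2 to compound 3 (1.52 log units; beyond the scatter).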

Compound 3, half-maximal inhibitory concentration: 4870 nM
Beside the measured number, compound 3's estimate is 1.6-fold (0.21 log units) below it; measured number inside the range.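

In this assay, the change gives an at least 20-fold lower number from compound 2 to compound 3 (1.31 log units; beyond the scatter), so a substituent on this aromatic carbon can keep measurable inhibition, and the loss seen with (3-hydroxycyclohexyl)amino does not extend to every replacement of the carboxy group. The methylcarbamoyl group does not fully match that carboxy group, however: the comparison gives a 2.9-fold higher number from compound 1 to compound 3 (0.46 log units; beyond the scatter), so methylamino in place of hydroxy on the carbonyl carbon carries a modest cost. Compound 2 stands only at a limit, so the first of these steps is a bound and not a measured size: the limit of > 100000 nM in this assay, at which 1 of the 3 values shown sits.

Going by these compounds, it remains open whether the loss in compound 2 follows from the amino link, the cyclohexane ring or its hydroxy group. On these data alone, it is also open whether a primary carboxamide, an ethyl amide or a tetrazole here would come closer to compound 1.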